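Amide to Azetidinyl Urea: Predicting the Next Step

The source may hold more compounds than are shown below. What is called first, only, known or untested is meant among the compounds shown, and "the series" means these compounds.

Three compounds sharing one core have been examined in a functional assay on MIA PaCa-2 cells (Homo sapiens) for inhibition, read by MTT assay, with a stated time of 3 days; a higher number here means a weaker inhibitor, a lower number a stronger inhibitor. Compound 2 `CCN(CC)C(=O)[C@@H]1CCCN(S(=O)(=O)c2ccc(S(=O)(=O)N(CC)CC)cc2)C1` gives the lowest number of the set, with 700 nM in this assay. Compound 3 `CCOC(=O)[C@@H]1C[C@@H](O)CN(S(=O)(=O)c2ccc(S(=O)(=O)N(CC)CC)cc2)C1` returns 2100 nM in this assay, and compound 1 `CCOC(=O)[C@@H]1CCCN(S(=N)(=O)c2ccc(S(=O)(=O)N(CC)CC)cc2)C1` returns 4700 nM in this assay, both higher numbers than compound 2, and both separations lie beyond the usual scatter. No pair among these three differs in only one place, so no single-point step can be drawn from them.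

Compound 4 `CCN(CC)S(=O)(=O)c1ccc(S(=O)(=O)N2CCC[C@@H](C(=O)NC3CN(C(=O)NC(C)(C)C)C3)C2)cc1` is built from compound 2 by one change: (1-((tert-butyl)carbamoyl)azetidin-3-yl)amino in place of diethylamino on a carbonyl carbon. Nothing measured here tells how this assay responds to such an exchange on the carbonyl carbon, so the direction of the step is uncertain. Given that compound 2 already holds the lowest number at 700 nM, the author expects compound 4 to land at 1500 nM, with a range from 300 nM to 7000 nM, which would mean an expected step of a 2.1-fold higher number from compound 2 to compound 4 (0.33 log units; beyond the scatter).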

Compound 4, half-maximal inhibitory concentration: 1400 nM
The estimate for compound 4 lay 1.1-fold (0.03 log units) above the measured number; the measured number falls inside the stated range.
By their numbers in this assay, from the lowest: compounds 2, 4 and 3 (each within the scatter of the next, the first and the last beyond it); then compound 1.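

For the compounds shown here, the step gives the first reading at a single place in this set: in this assay, putting (1-((tert-butyl)carbamoyl)azetidin-3-yl)amino in place of diethylamino on a carbonyl carbon gives a 2.0-fold higher number from compound 2 to compound 4 (0.30 log units; within the scatter), so the two compounds cannot be told apart. This position therefore accepts a much larger group, one that brings a four-membered non-aromatic ring and hydrogen-bond donors absent from diethylamino, with no change in the number that exceeds the usual scatter. Nothing available bears on why this exchange leaves the reading within the scatter.

The contributions of the azetidine ring and the tert-butyl urea cannot be separated here, and a methyl in place of the tert-butyl would be one way to part them. On these data alone, how this assay responds to a carboxylic acid or a simple methylamino at this carbonyl carbon also stays open.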